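From the carboxymethyl end of compound 3 to 2-chlorophenyl

The source may report more compounds than this note shows. Statements on the series, on what has been measured and on what is new or still open speak of the compounds shown alone.

Of the compounds shown here, three on a shared core have been measured. In a functional assay on a cell-free system (plasma, Oryctolagus cuniculus) for inhibition, with stated times of 5 min, 1 min and 6 min (on this read-out higher numbers stand for weaker inhibition and lower numbers for stronger inhibition), compound 1 `C=CCOn1c(-c2cccc(C#N)c2)nc(C)c1C(=O)OCC` gives 5860 nM. Compound 2 `CCOC(=O)c1c(C)nc(-c2cccc(C#N)c2)n1OCCCO` gives 11400 nM in this assay, and a 1.9-fold higher number from compound 1 to compound 2 (0.29 log units; within the scatter) leaves these two inseparable. Compound 3 `CCOC(=O)c1c(C)nc(-c2cccc(C#N)c2)n1OCCC(=O)O` reads > 30000 nM in this assay, which is a limit and not a number.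

Two steps lead to that limit: an at least 5.1-fold higher number from compound 1 to compound 3 (0.70 log units; beyond the scatter), and an at least 2.6-fold higher number from compound 2 to compound 3 (0.42 log units; beyond the scatter). Among the compounds with values here, both lie beyond the scatter, and compound 3 is the only measured compound carrying a carboxy group.

Compound 4 `CCOC(=O)c1c(C)nc(-c2cccc(C#N)c2)n1OCc1ccccc1Cl` has 2-chlorophenyl in place of carboxymethyl on a saturated chain carbon bound to an oxygen on an aromatic ring. Within the data shown here, the carboxy group is gone, as it is in compound 1 and compound 2, but no measured compound has an aromatic ring on this chain, so the entering group itself is untested.

The best available guide is an at least 5.1-fold higher number from compound 1 to compound 3 (0.70 log units; beyond the scatter), read in reverse. It points to a lower number in this assay, meaning stronger inhibition, with a wide margin for the untested group. The expected step is an at least 7.5-fold lower number from compound 3 to compound 4 (0.87 log units; beyond the scatter). Compound 4 is estimated at 4000 nM, with an expected range of 1000 nM to 16000 nM.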

Compound 4, half-maximal inhibitory concentration: 8710 nM
Compound 4: the middle estimate sits 2.2-fold (0.34 log units) below what was measured; measured number inside the range.
By their numbers in this assay, from the lowest: compounds 1, 4 and 2 (each within the scatter of the next). At a limit, above all of these: compound 3.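

In this assay, an aromatic ring on this chain proves compatible with a value in the range of the other uncharged-by-count, carboxy-free side chains: the change gives a 1.3-fold lower number from compound 2 to compound 4 (0.12 log units; within the scatter) and a 1.5-fold higher number from compound 1 to compound 4 (0.17 log units; within the scatter), so 2-chlorophenyl, with its 7 heavy atoms, cannot be told apart from 2-hydroxyethyl or vinyl at this position. Replacing carboxymethyl gives an at least 3.4-fold lower number from compound 3 to compound 4 (0.53 log units; beyond the scatter), which places compound 4 with compound 1 and compound 2 and leaves compound 3, the only compound shown with a carboxy group, apart from the other three. Compound 3 remains a limit and not a number, so the full size of that step cannot be read: the limit of > 30000 nM in this assay, at which 1 of the 4 values shown sits.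

The compounds shown leave open whether the chlorine matters at all, and a plain phenyl group on the same chain would separate the contribution of the ring from that of the halogen. Also open, from the compounds shown here alone, is how a primary amine at the end of the chain, or a methyl ester in place of the carboxy group, would read in this assay.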